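Adding chloro to compound 1

The source may report more compounds than this note shows. Statements on the series, on what has been measured and on what is new or still open speak of the compounds shown alone.

Compounds measured so far in an in vitro ADME assay on microsomes from liver (Homo sapiens) for metabolic stability (a lower number here means slower removal, a higher number faster removal of the compound), are these two:
- compound 1 `CN1CC(=O)N/C1=N\C(=O)Nc1ccncc1` gives 11 mL.min-1.g-1 as its intrinsic clearance
- compound 2 `Cc1cccnc1NC(=O)NC1=NC(=O)CN1C` gives 29 mL.min-1.g-1 as its intrinsic clearance

Compound 1 holds the lower number of the pair, and compound 2 lies above it by more than the usual scatter. Compound 3 `CN1CC(=O)N/C1=N\C(=O)Nc1ccncc1Cl` differs from compound 1 by one change chloro in place of hydrogen on an aromatic carbon at a place ortho to a large group and two atoms from the ring nitrogen. Within the data shown here, no measured pair shows a step of this kind, so the expectation rests on little. Among the measured compounds shown here, with compound 1 at 11 mL.min-1.g-1 as the lower of only two numbers, a rise seems likelier than a fall. The expected change in this assay is a small rise, estimated as a 1.5-fold higher number from compound 1 to compound 3 (0.19 log units; within the scatter) and perhaps not beyond the scatter. Compound 3 is expected at 17 mL.min-1.g-1 (estimated range 8 mL.min-1.g-1 to 38 mL.min-1.g-1).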

Compound 3, intrinsic clearance in microsomes: 15 mL.min-1.g-1
Compound 3: middle estimate off by 1.1-fold (0.05 log units), on the high side; low and high end bracket the measured number.
By their numbers in this assay, from the lowest: compounds 1, 3 and 2 (each within the scatter of the next, the first and the last beyond it).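

In this assay, chloro in place of hydrogen on an aromatic carbon, ortho to a large group and two atoms from the ring nitrogen, gives a 1.4-fold higher number from compound 1 to compound 3 (0.13 log units; within the scatter). Among these compounds, this is the first single-place step, and it shows that this position takes a chlorine atom with no shift beyond the usual scatter. No measured evidence bears on the reason for this result.

The compounds shown leave open whether an amine, a methoxy group or a nitrile at this same place would also stay within the scatter of compound 1. They also leave open whether chloro would give a similar step at another carbon of the ring, since this single step speaks for one position and one group only.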